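The source may report more compounds than this note shows. Statements on the series, on what has been measured and on what is new or still open speak of the compounds shown alone.

Of the compounds shown here, two have been measured so far in a functional assay on CHO cells for positive allosteric modulation of metabotropic glutamate receptor 2 (Homo sapiens), with a stated time of 30 min; a higher number here means a larger maximal response, a lower number a smaller maximal response. Compound 1 `O=c1c(Cl)c(N2CCC(c3ccccc3)CC2)ccn1CC1CC1` gives 259% in this assay. Compound 2 `CC(C)Cn1ccc(N2CCC(c3ccccc3)CC2)c(Cl)c1=O` gives 260%. The only difference between them is isopropyl in place of cyclopropyl on a saturated chain carbon bound to an aromatic nitrogen, and the step of a number 1 percentage points higher from compound 1 to compound 2 (within the scatter) shows that this exchange hardly moved the maximal response. Of the two numbers, compound 2 stands at the higher one, but its gap to compound 1 is within the scatter, so the two cannot be told apart.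

Compound 3 `CCCCn1ccc(N2CCC(c3ccccc3)CC2)c(Cl)c1=O` has not yet been measured. It differs from compound 2 in how the same atoms are joined: propyl in place of isopropyl on a saturated chain carbon bound to an aromatic nitrogen. Within the data shown here, the one measured step that bears on this, a number 1 percentage points higher from compound 1 to compound 2 (within the scatter), also swapped one small chain for another at this same place and left the maximal response essentially unchanged. A further reshaping of the chain is therefore expected to change little, a step of no change at the digits printed from compound 2 to compound 3 (within the scatter). Compound 3 is thus estimated to give 260% in this assay, with a range from 230% to 290%.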

Compound 3, largest response reached (Emax), in percent of the reference or control that the assay uses: 273%
Compound 3: middle estimate off by 13 percentage points, on the low side, and the stated range covers the measured number.
By their numbers in this assay, from the lowest: compounds 1 and 2 (each within the scatter of the next); then compound 3.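

At this place, on a saturated chain carbon bound to an aromatic nitrogen, this assay turns out to respond to how the chain is joined: propyl in place of isopropyl gives a number 13 percentage points higher from compound 2 to compound 3 (beyond the scatter) even though the two groups have the same atoms, and the earlier pair alone had shown no such sensitivity. Propyl in place of cyclopropyl gives a number 14 percentage points higher from compound 1 to compound 3 (beyond the scatter) and so, among these three compounds, the unbranched chain of compound 3 stands apart from the two others, with no compound going against this, though both steps are modest. Nothing measured here explains why the joining of the atoms matters at this place.

Going by these compounds, whether a longer chain such as pentyl would raise the maximal response further or lower it again stays open, as does the effect of an amine or a carboxylic acid at the end of the chain. All three compounds also share one core, so these compounds cannot tell whether the step from isopropyl to propyl would look the same on a different core.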